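The source may report more compounds than this note shows. Statements on the series, on what has been measured and on what is new or still open speak of the compounds shown alone.

Three compounds have been measured in an assay on cells with melanin-concentrating hormone receptor 1 (Homo sapiens) as the target, read by radioligand binding; a higher number here means a weaker inhibitor, a lower number a stronger inhibitor:

Compound 1, `CCOCCOc1cccc2ccc(N)nc12`, gives only a limit of the assay, > 2000 nM.
Compound 2, `CCCOc1cccc2ccc(N)nc12`, gives 1100 nM.
Compound 3, `Nc1ccc2cccc(OCC3CC3)c2n1`, gives only a limit of the assay, > 2000 nM.

Compound 1 therefore stands at the edge of what this assay can report, a position it shares with one other compound (the limit of > 2000 nM in this assay, at which 2 of the 3 values shown sit). The unmeasured compound 4, `CC(C)=CCOc1cccc2ccc(N)nc12`, differs from compound 1 in a single place: 2-methylprop-1-en-1-yl in place of ethoxymethyl on a saturated chain carbon bound to an oxygen on an aromatic ring. Among the compounds with values here, two measured steps bear on this change. The step of an at least 1.8-fold lower number from compound 1 to compound 2 (0.25 log units; that floor lies within the scatter) also does away with the hydrogen-bond acceptor in the chain and gives a lower number, although its floor lies within the scatter. The step of an at least 1.8-fold higher number from compound 2 to compound 3 (0.25 log units; that floor lies within the scatter), which brings in a ring on the chain, moves the number the other way, again only at the edge of the scatter. Compound 4 likewise loses the acceptor and carries a branched chain with a double bond, so compound 4 is expected to land at a lower number, by the step of an at least 2.2-fold lower number from compound 1 to compound 4 (0.34 log units; beyond the scatter). For compound 4 the estimate in this assay is 900 nM, with a range from 250 nM to 3500 nM.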

Compound 4, half-maximal inhibitory concentration: > 2000 nM
Compound 4 gave a limit, no number (the forecaster's own chance of this, stated with the estimate: 35%); at least 2.2-fold (0.34 log units) between middle value and limit.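

In this assay compound 4 reaches only a limit of the assay, so replacing ethoxymethyl with 2-methylprop-1-en-1-yl takes the hydrogen-bond acceptor out of the group without bringing a readable number, and losing that acceptor is not enough on its own to do so here. Replacing ethyl with the same group gives an at least 1.8-fold higher number from compound 2 to compound 4 (0.25 log units; that floor lies within the scatter), so this comparison does not clearly separate compound 4 from compound 2, while the steps to compound 1 and compound 3 cannot be read, as both ends of each are limits. Compound 2 is still the only compound with a number at this place on the chain, and the rest of the set has gathered at the edge of the assay: the limit of > 2000 nM in this assay, at which 3 of the 4 values shown sit.

From the compounds shown here alone, how far compound 1, compound 3 and compound 4 lie past that limit remains unknown, which leaves their order open. Within the data shown here, also open is whether a butyl chain or a chain carrying an amine would give a number, and how that number would compare with the one for compound 2.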